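The source may hold more compounds than are shown below. What is called first, only, known or untested is meant among the compounds shown, and "the series" means these compounds.

Compound 1 `CCOC(=O)C1=Cc2ccccc2OC1(OCc1cn(-c2ccc(F)cc2)nn1)C(F)(F)F`: 9100 nM
Compound 2 `CCOC(=O)C1=Cc2ccccc2OC1(OCc1cn(-c2ccc(F)c([N+](=O)[O-])c2)nn1)C(F)(F)F`: 16200 nM
Compound 3 `COc1ccc(-c2cc(COC3(C(F)(F)F)Oc4ccccc4C=C3C(=O)O)on2)cc1`: 35200 nM

Of the compounds shown here, three sharing one core have been tested in a functional assay on MCF7 cells (Homo sapiens) for inhibition, read by MTT assay, with a stated time of 24 h; a lower number here means a stronger inhibitor, a higher number a weaker inhibitor. Compound 1 gives the lowest number of the three, though its gap to compound 2 is within the scatter, so those two cannot be ranked against each other. Compound 3 differs from compound 1 in more than one place, and its number stands clearly higher, beyond the scatter.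

Compound 4 `CCOC(=O)C1=Cc2ccccc2OC1(OCc1cn(-c2ccc(F)c(Cl)c2)nn1)C(F)(F)F` has not yet been measured. It differs from compound 1 in one place: chloro in place of hydrogen on an aromatic carbon

Within the data shown here, only one measured step bears on this change. Compound 2 carries a nitro group at the very same aromatic carbon where compound 4 carries chloro, and a 1.8-fold higher number from compound 1 to compound 2 (0.25 log units; within the scatter). That step stayed within the scatter, so a single small substituent at this position has not so far moved the number in this assay by more than the usual spread. Among the measured compounds shown here, with no other step to draw on, no movement beyond the scatter is expected for compound 4 either. The step from compound 1 expected for it is a 1.0-fold higher number from compound 1 to compound 4 (0.02 log units; within the scatter). Compound 4 is therefore estimated to give 9500 nM, with a plausible range from 4000 nM to 22000 nM.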

Compound 4, half-maximal inhibitory concentration: 25300 nM
For compound 4 the middle estimate is 2.7-fold (0.43 log units) below the measured one; measured number outside the range, above it.
By their numbers in this assay, from the lowest: compounds 1, 2, 4 and 3 (each within the scatter of the next, the first and the last beyond it).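

In this assay, the change from 4-fluorophenyl to 3-chloro-4-fluorophenyl gives a 2.8-fold higher number from compound 1 to compound 4 (0.44 log units; beyond the scatter), so a single added atom on this aromatic carbon, ortho to the fluoro group, can make the compound a modestly weaker inhibitor, a shift the nitro group of compound 2 did not clearly produce. Even so, chloro and nitro cannot be ranked against each other at this carbon: the comparison gives a 1.6-fold higher number from compound 2 to compound 4 (0.19 log units; within the scatter), so the clear separation from compound 1 holds for compound 4 alone, while compound 2 sits within the scatter of both. Nothing available here explains why chloro at this carbon separates from hydrogen.

The compounds shown leave open whether a methyl, a methoxy, an amine or a carboxylic acid on this same carbon would stay close to compound 1 or move as far as chloro does. They also leave open whether chloro would give a step of similar size on another carbon of the ring, since only this one carbon has been varied among the compounds shown.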